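This account rests on a few compounds, and the source may have more. Where it says the series, first, only, none or still open, it means among the compounds named here.

Compound 1 `CC(C)=CCn1nc(-c2cccnc2)c2ccccc2c1=O` is the starting point. Going by the values given here, in a functional assay (trachea) with Cavia porcellus as the target (on this read-out lower numbers stand for stronger inhibition and higher numbers for weaker inhibition), compound 1 gives 1380 nM, the lowest of the three numbers measured so far. Compound 2 `COCCn1nc(-c2cccnc2)c2ccccc2c1=O` gives 9330 nM in this assay, and compound 3 `O=c1c2ccccc2c(-c2cccnc2)nn1S(=O)(=O)c1ccccc1` gives 14800 nM, so both show weaker inhibition than compound 1, and the steps are beyond the usual scatter.

Compound 4 `CC(C)NC(=O)CCCn1nc(-c2cccnc2)c2ccccc2c1=O` differs from compound 1 in one place: 2-(isopropylcarbamoyl)ethyl in place of 2-methylprop-1-en-1-yl on a saturated chain carbon bound to an aromatic nitrogen. Among the compounds with values here, the only measured step that changes the same place is a 6.8-fold higher number from compound 1 to compound 2 (0.83 log units; beyond the scatter), where a small chain carrying an oxygen replaced the same 2-methylprop-1-en-1-yl group. Compound 4 carries a longer chain with an amide in that place, so a step of similar size in the same direction, toward weaker inhibition, is expected, while the data give no ground for expecting stronger inhibition. Compound 4 is therefore estimated at 5500 nM in this assay, with a range from 1800 nM to 17000 nM. This estimate for compound 4 means an expected step of a 4.0-fold higher number from compound 1 to compound 4 (0.60 log units; beyond the scatter).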

Compound 4, half-maximal inhibitory concentration: 64600 nM
Compound 4: the middle estimate sits 12-fold (1.07 log units) below what was measured; measured number outside the range, above it.
By their numbers in this assay, from the lowest: compound 1; then compounds 2 and 3 (each within the scatter of the next); then compound 4.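

In this assay, the place on a saturated chain carbon bound to an aromatic nitrogen turns out to be far less forgiving than the first step suggested: putting 2-(isopropylcarbamoyl)ethyl in place of 2-methylprop-1-en-1-yl gives a 47-fold higher number from compound 1 to compound 4 (1.67 log units; beyond the scatter) and is a large step. The amide chain also stands apart from the oxygen-bearing chain, with a 6.9-fold higher number from compound 2 to compound 4 (0.84 log units; beyond the scatter) for (isopropylcarbamoyl)methyl in place of methoxy, so among compounds 1, 2 and 4 this chain gives the weakest inhibition. Nothing measured here explains why this chain weakens inhibition so strongly.

The compounds shown leave open whether the amide or the sheer length of the chain matters more, a question that a plain longer carbon chain would help to settle. From the compounds shown here alone, how a chain ending in an amine or a carboxylic acid would compare also stays open.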